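Replacing chloro with methoxy in compound 2

The source may report more compounds than this note shows. Statements on the series, on what has been measured and on what is new or still open speak of the compounds shown alone.

compound 1 `COc1ccc(C(=O)N2CCN(CC(=O)N3CCN(CCCc4c[nH]c5ccc(F)cc45)CC3)CC2)cc1` gives 161000 nM
compound 2 `O=C(CN1CCN(C(=O)c2cccc(Cl)c2)CC1)N1CCN(CCCc2c[nH]c3ccc(F)cc23)CC1` gives 59800 nM

In an ADME assay on SH-SY5Y cells (Homo sapiens) for cytotoxicity, read by MTT assay, with a stated time of 72 h (on this read-out lower numbers stand for stronger inhibition and higher numbers for weaker inhibition), compound 2 holds the lower of the two numbers, at 59800 nM. Compound 3 `COc1cccc(C(=O)N2CCN(CC(=O)N3CCN(CCCc4c[nH]c5ccc(F)cc45)CC3)CC2)c1` carries methoxy in place of chloro on an aromatic carbon. Within the data shown here, only one measured step bears on this, a 2.7-fold lower number from compound 1 to compound 2 (0.43 log units; beyond the scatter), a modest one that also moves from a methoxy-bearing ring to a chloro-bearing ring. Returning to methoxy should undo part or all of it, so a similarly modest rise is expected, as a 1.8-fold higher number from compound 2 to compound 3 (0.26 log units; within the scatter). Compound 3 is estimated at 110000 nM, with a range of 50000 nM to 240000 nM.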

Compound 3, half-maximal inhibitory concentration: 79400 nM
Beside the measured number, compound 3's estimate is 1.4-fold (0.14 log units) above it; low and high end bracket the measured number.
By their numbers in this assay, from the lowest: compounds 2 and 3 (each within the scatter of the next); then compound 1.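

In this assay chloro and methoxy on this aromatic carbon, meta to a large group, cannot be told apart, with a 1.3-fold higher number from compound 2 to compound 3 (0.12 log units; within the scatter). The change of 4-methoxyphenyl to 3-methoxyphenyl does register, with a 2.0-fold lower number from compound 1 to compound 3 (0.31 log units; beyond the scatter), so across these three compounds the number follows where the group sits more than which of the two groups it is. Nothing available here explains this difference.

As far as these compounds go, whether an amine or a carboxylic acid on this same ring carbon would fit that reading stays open. So does whether it holds on a different shared core.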